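Replacing 4-acetylpiperazin-1-yl with anilino in compound 3

A few compounds are considered here, and "the series" means these few. Any claim that something is new, unique, unknown or untested is made for them only; others in the source may bear on it.

Measured compounds, with values from a functional assay on HeLa cells (Homo sapiens) for antiproliferative activity, read by spectrophotometry, with a stated time of 2 days; on this read-out higher numbers stand for weaker inhibition of growth and lower numbers for stronger inhibition of growth
Compound 1 `CC(=O)N1CCN(c2ccc(Nc3ncc(C(F)(F)F)c(N4Cc5cccc(N(C)S(C)(=O)=O)c5C4)n3)cc2)CC1` gives 730 nM
Compound 2 `COc1cc(N2CCN(C(C)=O)CC2)ccc1Nc1ncc(C(F)(F)F)c(N2Cc3cccc(N(C)S(C)(=O)=O)c3C2)n1` gives 1300 nM

Among the measured compounds shown here, compound 1 (730 nM) stands level with compound 2 (1300 nM), the only other measured compound, and the two lie within the scatter of each other. Compound 3 `CN(c1cccc2c1CN(c1nc(Nc3ccc(Nc4ccccc4)cc3)ncc1C(F)(F)F)C2)S(C)(=O)=O` keeps the core of compound 1 but carries anilino in place of 4-acetylpiperazin-1-yl on an aromatic carbon, para to a large group (anilino in place of 4-acetylpiperazin-1-yl on an aromatic carbon). For the measured compounds named here, the one measured step, a 1.8-fold higher number from compound 1 to compound 2 (0.25 log units; within the scatter), is methoxy in place of hydrogen on an aromatic carbon. Going by the values given here, it leaves 4-acetylpiperazin-1-yl untouched, so it bears only weakly on this exchange, and no measured compound lacks that group. In this assay no step beyond the scatter is therefore expected, though with wide uncertainty. The estimated step is a 1.2-fold higher number from compound 1 to compound 3 (0.09 log units; within the scatter) in this account. Compound 3 is expected at 900 nM, with an estimated range of 250 nM to 3200 nM around it.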

Compound 3, concentration for 50% growth inhibition: 7300 nM
The estimate for compound 3 lay 8.1-fold (0.91 log units) below the measured number; the whole stated range lies below it.
By their numbers in this assay, from the lowest: compounds 1 and 2 (each within the scatter of the next); then compound 3.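

The exchange at this aromatic carbon, para to a large group, gives in this assay a 10-fold higher number from compound 1 to compound 3 (1.00 log units; beyond the scatter) and is the only step among these compounds to go beyond the scatter. The position is therefore not indifferent to what it carries: 4-acetylpiperazin-1-yl is tolerated better here than anilino. The exchange replaces a six-membered non-aromatic ring with an aromatic ring of carbon only and adds a hydrogen-bond donor, and nothing available explains the step or separates these differences.

The compounds shown leave open whether morpholin-4-yl, piperazin-1-yl without its acetyl, or a plain amine at this place would stay near compound 1 or move towards compound 3. They also leave open whether N-methylanilino, which has no hydrogen-bond donor on its nitrogen, would behave like anilino.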